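A few compounds are considered here, and "the series" means these few. Any claim that something is new, unique, unknown or untested is made for them only; others in the source may bear on it.

Three compounds share one core. Compound 1 `Cc1ccccc1C#Cc1ccc2c(n1)CCN(C)C2=O` gives in an assay on HEK293 cells for displacement of a labelled ligand from metabotropic glutamate receptor 5 (Homo sapiens), with a stated time of 2 h (on this read-out higher numbers stand for weaker inhibition and lower numbers for stronger inhibition), a result of > 32000 nM, which is a limit of the assay rather than a number (the limit of > 32000 nM in this assay, at which 1 of the 3 values shown sits). Compound 2 `Cc1ccc(C#Cc2ccc3c(n2)CCN(C)C3=O)cc1` gives 7450 nM in this assay, and compound 3 `CN1CCc2nc(C#Cc3cccc(Cl)c3)ccc2C1=O` gives 250 nM, the lowest of the two numbers shown, with the step of a 30-fold lower number from compound 2 to compound 3 (1.47 log units; beyond the scatter) beyond the scatter. Compound 4 `CN1CCc2nc(C#Cc3ccccn3)ccc2C1=O` differs from compound 3 by pyridin-2-yl in place of 3-chlorophenyl on a triple-bonded carbon. Within the data shown here, the steps that bear on this change all alter the ring on the triple-bonded carbon: an at least 4.2-fold lower number from compound 1 to compound 2 (0.63 log units; beyond the scatter), an at least 120-fold lower number from compound 1 to compound 3 (2.10 log units; beyond the scatter) and a 30-fold lower number from compound 2 to compound 3 (1.47 log units; beyond the scatter). Because compound 3 gives 250 nM, the lowest value seen, replacing its 3-chlorophenyl is expected to raise the number, a step of a 12-fold higher number from compound 3 to compound 4 (1.08 log units; beyond the scatter). Compound 4 is therefore estimated at 3000 nM, between 600 nM and 15000 nM.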

Compound 4, inhibition constant: 6240 nM
Compound 4: middle estimate off by 2.1-fold (0.32 log units), on the low side, and the stated range covers the measured number.
By their numbers in this assay, from the lowest: compound 3; then compounds 4 and 2 (each within the scatter of the next). At a limit, above all of these: compound 1.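

In this assay, pyridin-2-yl on the triple-bonded carbon, the only ring here with a hetero atom, does not keep the level of 3-chlorophenyl (a 25-fold higher number from compound 3 to compound 4 (1.40 log units; beyond the scatter)). It cannot be told apart from 4-methylphenyl (a 1.2-fold lower number from compound 2 to compound 4 (0.08 log units; within the scatter)), while against 2-methylphenyl the number falls (an at least 5.1-fold lower number from compound 1 to compound 4 (0.70 log units; beyond the scatter)). The value of compound 1 is a limit of the assay: the limit of > 32000 nM in this assay, at which 1 of the 4 values shown sits.

Still open, as far as these compounds go, is whether 3-methylphenyl, 3-bromophenyl or pyridin-3-yl on this carbon would come closer to compound 3.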